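Ortho-Chlorophenyl Variant of a Pyrazole Carboxylic Acid Series

A few compounds are considered here, and "the series" means these few. Any claim that something is new, unique, unknown or untested is made for them only; others in the source may bear on it.

Measured compounds:
compound 1 `COc1ccc(-c2c(C)nn(-c3nc(-c4ccc(Cl)c(Cl)c4)c(SC(C)C)s3)c2C(=O)O)cc1`, 2100 nM
compound 2 `Cc1ccccc1-c1c(C)nn(-c2nc(-c3ccc(Cl)c(Cl)c3)c(SC(C)C)s2)c1C(=O)O`, 5500 nM
compound 3 `Cc1ccc(-c2c(C)nn(-c3nc(-c4ccc(Cl)c(Cl)c4)c(SC(C)C)s3)c2C(=O)O)cc1`, 3800 nM

In a functional assay on BJAB cells (Homo sapiens) for antiproliferative activity, with a stated time of 4 days (a higher number here means that more compound is needed for the effect, a lower number that less compound is needed), compound 3 stands second highest of the three numbers; its gap to compound 2 is within the scatter, and its gap to compound 1 is likewise within the scatter. The unmeasured compound 4 `Cc1nn(-c2nc(-c3ccc(Cl)c(Cl)c3)c(SC(C)C)s2)c(C(=O)O)c1-c1ccccc1Cl` differs from compound 3 by 2-chlorophenyl in place of 4-methylphenyl on an aromatic carbon. Going by the values given here, two measured steps bear on this: a 1.4-fold lower number from compound 2 to compound 3 (0.16 log units; within the scatter), showing that moving a methyl from one position of the phenyl to the other changes little, and a 2.6-fold higher number from compound 1 to compound 2 (0.42 log units; beyond the scatter), a modest rise. Among the compounds with values here, no measured step exchanges methyl for chlorine. Compound 4 is therefore expected to give a number near that of compound 3 or modestly higher, an estimated step of a 1.3-fold higher number from compound 3 to compound 4 (0.12 log units; within the scatter). The estimated value for compound 4 is 5000 nM, within a range of 2000 nM to 12000 nM.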

Compound 4, half-maximal effective concentration: 13100 nM
Estimate against measurement, compound 4: 2.6-fold (0.42 log units) below, and the stated range ends below it.
By their numbers in this assay, from the lowest: compounds 1, 3 and 2 (each within the scatter of the next, the first and the last beyond it); then compound 4.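

Going from 2-methylphenyl to 2-chlorophenyl at this position, a chloro-for-methyl exchange the earlier compounds did not cover, gives a 2.4-fold higher number from compound 2 to compound 4 (0.38 log units; beyond the scatter) in this assay. Replacing 4-methylphenyl gives a larger change, a 3.4-fold higher number from compound 3 to compound 4 (0.54 log units; beyond the scatter), so the two methylphenyl groups, which stood within the scatter of each other, both give lower numbers than 2-chlorophenyl. The widest gap in the set is a 6.2-fold higher number from compound 1 to compound 4 (0.80 log units; beyond the scatter).

Nothing available here explains why the chloro compound needs more compound for the effect. From the compounds shown here alone, whether a phenyl bearing fluoro, hydroxy or an amine would follow compound 4 or compound 1 remains open.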